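The source may report more compounds than this note shows. Statements on the series, on what has been measured and on what is new or still open speak of the compounds shown alone.

The measured compounds:
Compound 1, `COc1cc2c(Nc3cccc(F)c3F)ncnc2c(OC)c1OC`: in a functional assay on SGC-7901 cells (Homo sapiens) for antiproliferative activity, read by MTT assay, with a stated time of 72 h (on this read-out lower numbers stand for stronger inhibition and higher numbers for weaker inhibition), compound 1 gives only a limit, not a number, > 30000 nM.
Compound 2, `COc1cc2c(Nc3ccc(Br)c(F)c3)ncnc2c(OC)c1OC`: in this assay compound 2 also gives only a limit, > 30000 nM.
Compound 3, `COc1cc2c(Nc3cccc(C(F)(F)F)c3)ncnc2c(OC)c1OC`: in this assay compound 3 likewise gives only a limit, > 30000 nM.

Compound 3 thus stands where every measured compound stands, at the limit of > 30000 nM in this assay, at which 3 of the 3 values shown sit. For the measured compounds named here, since none of these values is a real number, no compound can be ranked against another. Going by the values given here, the single one-place comparison among them, a step that the two limits leave unreadable from compound 1 to compound 2, is unreadable for the same reason, as both of its ends are limits.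

Compound 4, `COc1cc2c(Nc3cccc(I)c3)ncnc2c(OC)c1OC`, is the compound not yet measured. It differs from compound 3 by iodo in place of trifluoromethyl on an aromatic carbon. Among the compounds with values here, no measured step touches an iodo group, and the one step that exists has no readable size, so nothing points to a change in this assay in either direction beyond the scatter. The expected step is a step that the limit leaves unreadable from compound 3 to compound 4. For compound 4 the estimated value is 40000 nM, in the range 8000 nM to 200000 nM, with a real chance that only a limit is reported again.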

Compound 4, half-maximal inhibitory concentration: 8640 nM
For compound 4 the middle estimate is 4.6-fold (0.67 log units) above the measured one, within the range that was stated.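

In this assay, for the compounds shown here, iodo in place of trifluoromethyl on this aromatic carbon gives an at least 3.4-fold lower number from compound 3 to compound 4 (0.54 log units; beyond the scatter), the first sign that a change on the aniline ring can move this read-out at all. Going by these compounds alone, the same holds against the two other rings, with an at least 3.4-fold lower number from compound 2 to compound 4 (0.54 log units; beyond the scatter) and an at least 3.4-fold lower number from compound 1 to compound 4 (0.54 log units; beyond the scatter), while the step among the earlier compounds stays unreadable. Compound 4 is the only one with a real number, and each of these steps is a minimum, as the other end is a limit: the limit of > 30000 nM in this assay, at which 3 of the 4 values shown sit.

From the compounds shown here alone, whether this gain belongs to iodo alone stays open, since a single compound cannot show a trend across groups. Chloro, an amine or a methoxy group on the same aromatic carbon would show whether other groups also give a real number here.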